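Benzyl to Ethyl in a Series Without Readable Activity

The compounds below may be only part of what the source reports. "The series", "measured", "known", "first", "only" and "open" are said of these compounds alone.

Measured compounds:
compound 1 `Cc1ccc2c(c1)C1(C(=O)N2Cc2ccccc2)C(C#N)=C(N)Oc2cc3oc(-c4ccccc4)cc(=O)c3c(O)c21` — > 50000 nM
compound 2 `Cc1cccc2c1N(Cc1ccccc1)C(=O)C21C(C#N)=C(N)Oc2cc3oc(-c4ccccc4)cc(=O)c3c(O)c21` — > 50000 nM
compound 3 `CCN1C(=O)C2(C(C#N)=C(N)Oc3cc4oc(-c5ccccc5)cc(=O)c4c(O)c32)c2cccc(C)c21` — > 50000 nM

In a functional assay on NCI-H1299 cells (Homo sapiens) for antiproliferative activity, read by MTT assay, with a stated time of 48 h (on this read-out higher numbers stand for weaker inhibition and lower numbers for stronger inhibition), compound 1 gives > 50000 nM, which is a limit of the assay and not a number. Compound 2 gives > 50000 nM in this assay, again a limit. Compound 3 likewise gives > 50000 nM in this assay, a limit. Compound 1 and compound 2 share the same atoms joined differently; the difference between the two cores is not broken down here.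

From compound 2 to compound 3 the change is methyl in place of phenyl on a saturated chain carbon bound to an amide-type nitrogen in a ring. The step that the two limits leave unreadable from compound 2 to compound 3 cannot be read, because the limit of > 50000 nM in this assay, at which 3 of the 3 values shown sit, leaves both ends of it as limits.

Compound 4 `CCN1C(=O)C2(C(C#N)=C(N)Oc3cc4oc(-c5ccccc5)cc(=O)c4c(O)c32)c2cc(C)ccc21` has not yet been measured in this assay. It differs from compound 1 by methyl in place of phenyl on a saturated chain carbon bound to an amide-type nitrogen in a ring, the same change as that from compound 2 to compound 3, made at the same place, word for word, on the core of compound 1 rather than the core of compound 2. Since that earlier step was unreadable and every measured value sits at the limit, compound 4 is expected to remain at the limit as well, so the step that the limit leaves unreadable from compound 1 to compound 4 is expected to be no more than nominal. Compound 4 is therefore estimated at 60000 nM in this assay, with a range from 20000 nM to 200000 nM.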

Compound 4, half-maximal inhibitory concentration: > 50000 nM
Compound 4: a limit, no number; the forecaster's own chance of this, stated with the estimate: 85%; the middle value lies beyond the limit too.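

In this assay compound 4 gives > 50000 nM, a limit of the assay and not a number. No new step can be read between compound 1 and compound 4, because both ends of the benzyl to ethyl change are limits: the limit of > 50000 nM in this assay, at which 4 of the 4 values shown sit.

The compounds shown leave open how far each lies beyond that limit, and whether benzyl or ethyl makes any difference on either core.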